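Hydroxyethoxypyridine Replaces Hydroxypropylpyrazole on the Anilinic Nitrogen

A few compounds are considered here, and "the series" means these few. Any claim that something is new, unique, unknown or untested is made for them only; others in the source may bear on it.

Of the compounds shown here, three sharing one core have been measured in a functional assay on HCT-116 cells (Homo sapiens) for antiproliferative activity, read by sulforhodamine B assay, with a stated time of 72 h; on this read-out lower numbers stand for stronger inhibition and higher numbers for weaker inhibition. Compound 1 `COc1ncc(-c2ccc3ncnc(Nc4ccc(OCCO)c(F)c4)c3c2)cc1NS(=O)(=O)c1ccc(F)cc1F` gives 9160 nM. Among the measured compounds shown here, compound 3 `COc1cc(Nc2ncnc3ccc(-c4cnc(OC)c(NS(=O)(=O)c5ccc(F)cc5F)c4)cc23)ccc1OCCO` gives 5720 nM; the single change between them, a 1.6-fold lower number from compound 1 to compound 3 (0.20 log units; within the scatter), is the only one-place step among the measured compounds. Compound 2 `COc1ncc(-c2ccc3ncnc(Nc4cnn(CCCO)c4)c3c2)cc1NS(C)(=O)=O` gives 1420 nM, the lowest of the three numbers, and its distance to both compound 3 and compound 1 lies beyond the scatter.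

Compound 4 `COc1ncc(-c2ccc3ncnc(Nc4ccc(OCCO)nc4)c3c2)cc1NS(C)(=O)=O` follows from compound 2 by one change: 6-(2-hydroxyethoxy)pyridin-3-yl in place of 1-(3-hydroxypropyl)-1H-pyrazol-4-yl on a nitrogen on an aromatic ring. For the measured compounds named here, no measured step isolates this change. Compound 1 and compound 3 carry a six-membered aromatic ring on that nitrogen, but they also carry a different sulfonamide, so their higher numbers cannot be assigned to the ring alone, and the step of a 1.6-fold lower number from compound 1 to compound 3 (0.20 log units; within the scatter) concerns a substituent elsewhere. The expectation for compound 4 therefore rests on compound 2 itself, with room for movement in either direction and no firm grounds for a shift beyond the scatter. Compound 4 is expected to show a step of a 1.5-fold higher number from compound 2 to compound 4 (0.19 log units; within the scatter) in this assay. The estimate for compound 4 is 2200 nM, with a range from 700 nM to 7000 nM.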

Compound 4, half-maximal inhibitory concentration: 5360 nM
Compound 4: middle estimate off by 2.4-fold (0.39 log units), on the low side; measured number inside the range.
By their numbers in this assay, from the lowest: compound 2; then compounds 4, 3 and 1 (each within the scatter of the next).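

In this assay, among the compounds shown here, the step of a 3.8-fold higher number from compound 2 to compound 4 (0.58 log units; beyond the scatter) is the first reading that isolates the group on this nitrogen, since the rest of the molecule stays the same and the earlier step of a 1.6-fold lower number from compound 1 to compound 3 (0.20 log units; within the scatter) concerned a substituent elsewhere. It shows that this position is not indifferent to the exchange: 6-(2-hydroxyethoxy)pyridin-3-yl gives a higher number than 1-(3-hydroxypropyl)-1H-pyrazol-4-yl, even though the two groups have the same hydrogen-bond donor and acceptor counts and neither carries a net charge. Nothing available bears on why the number moves.

The change alters the ring and the chain together, so the compounds shown do not separate their contributions; a 1-(2-hydroxyethyl)-1H-pyrazol-4-yl group, or a pyrazole whose 3-hydroxypropyl chain ends in an amine instead of the hydroxyl, would help to divide them. On these data alone, it also remains open whether the same exchange would give a step of similar size with the sulfonamide carried by compound 1 and compound 3.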